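Anilide variation on the shared core: cytotoxicity working notes

The compounds below may be only part of what the source reports. "The series", "measured", "known", "first", "only" and "open" are said of these compounds alone.

Compound 1 `CCc1cccc(NC(=O)c2cccc(/C=C3\CC(=O)N(c4ccccc4)C3=O)c2)c1` gives 88600 nM in an ADME assay on SW480 cells (Homo sapiens) for cytotoxicity, read by MTT assay, with a stated time of 72 h; on this read-out lower numbers stand for stronger inhibition and higher numbers for weaker inhibition.
Compound 2 `COc1ccc(NC(=O)c2cccc(/C=C3\CC(=O)N(c4ccccc4)C3=O)c2)c(C)c1` gives > 100000 nM, a limit of the assay rather than a number.
Compound 3 `O=C(Nc1cccc(F)c1)c1cccc(/C=C2\CC(=O)N(c3ccccc3)C2=O)c1` gives > 100000 nM, likewise a limit.

Compound 3 stands at the ceiling of the numbers shown: the limit of > 100000 nM in this assay, at which 2 of the 3 values shown sit. Its steps from the other two are therefore only partly readable: an at least 1.1-fold higher number from compound 1 to compound 3 (0.05 log units; that floor lies within the scatter), and a step that the two limits leave unreadable from compound 2 to compound 3.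

Compound 4 `COc1ccc(OC)c(NC(=O)c2cccc(/C=C3\CC(=O)N(c4ccccc4)C3=O)c2)c1` is the next anilide variant, changed as follows: 2,5-dimethoxyphenyl in place of 3-fluorophenyl on an amide-type nitrogen. Among the compounds with values here, the one step that bears on a methoxy-bearing anilide, an at least 1.1-fold higher number from compound 1 to compound 2 (0.05 log units; that floor lies within the scatter), ends at the limit and is only a floor within the scatter. Compound 2, which also carries a methoxy on its anilide ring, sits at the limit. Nothing among the three values points to a number inside the measurable range, and from compound 3, itself at the limit, no readable step is expected: a number no higher from compound 3 to compound 4 (the limit leaves the size open).

Compound 4 is accordingly estimated at 100000 nM, with an expected range from 40000 nM to 300000 nM, most likely reported again only as a limit.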

Compound 4, half-maximal inhibitory concentration: > 100000 nM
Compound 4: no number, only a limit; the forecaster's own chance of this, stated with the estimate: 70%; the middle value sits exactly at the limit.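

The 2,5-dimethoxyphenyl group on the amide-type nitrogen ends at the same ceiling in this assay as 3-fluorophenyl and 4-methoxy-2-methylphenyl, so a second methoxy-bearing anilide also gives only a limit, and the ceiling now holds most of the values: the limit of > 100000 nM in this assay, at which 3 of the 4 values shown sit.

Within the data shown here, the only readable comparison is an at least 1.1-fold higher number from compound 1 to compound 4 (0.05 log units; that floor lies within the scatter), a floor that does not by itself set compound 1 apart. The steps linking compound 4 to compound 2 and to compound 3 run between two limits and cannot be read.

Among these compounds, compound 1, with 3-ethylphenyl, remains the only anilide with a number, 88600 nM, and whether other anilides reach the measurable range stays open. Also open, as far as these compounds go, is what an anilide ring carrying an amine, a carboxylic acid or a longer alkyl chain would give in this assay.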